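The source may report more compounds than this note shows. Statements on the series, on what has been measured and on what is new or still open speak of the compounds shown alone.

Measured in a physicochemical assay for lipophilicity; on this read-out lower numbers stand for lower lipophilicity and higher numbers for higher lipophilicity:

- Compound 1 `Clc1cccc(Cl)c1C1=NC(c2ccccc2)CO1` gives 3.69
- Compound 2 `Fc1ccccc1C1=NC(c2ccccc2)CO1` gives 3.51
- Compound 3 `Fc1cccc(F)c1C1=NC(c2ccccc2)CO1` gives 3.01

Compound 2, at 3.51, lies within the usual scatter of compound 1, at 3.69, so these two cannot be told apart on this read-out. Among the measured compounds shown here, compound 3 stands clearly lower, and the gap is the one measured step in the set: a number 0.50 log units lower from compound 2 to compound 3 (beyond the scatter).

The unmeasured compound 4 `Brc1ccccc1C1=NC(c2ccccc2)CO1` is reached from compound 2 by one change: bromo in place of fluoro on an aromatic carbon. Put simply, bromo replaces fluoro on an aromatic carbon, ortho to a large group. For the measured compounds named here, the one measured step is a different change, fluoro in place of hydrogen, so it gives a sense of how large a single exchange can be in this set, but no bromo compound has been measured. Going by the values given here, the only other guide is the pair of values for compound 3, at 3.01, and compound 1, at 3.69, of which compound 1 is the higher.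

On this thin evidence, a modest rise in this assay is expected, similar in size to the measured step but opposite in direction. The expected change is a number 0.39 log units higher from compound 2 to compound 4 (beyond the scatter). For compound 4 the estimated value is 3.9, with an expected range from 3.55 to 4.25.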

Compound 4, partition coefficient: 3.69
Estimate against measurement, compound 4: 0.21 log units above; the range from low to high includes it.
By their numbers in this assay, from the lowest: compound 3; then compounds 2, 1 and 4 (each within the scatter of the next).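

In this assay the exchange of fluoro for bromo on this aromatic carbon, ortho to a large group, gives a number 0.18 log units higher from compound 2 to compound 4 (within the scatter) and so does not separate the two halogens at this place on this read-out. The earlier compounds shown here offered only fluoro in place of hydrogen, a number 0.50 log units lower from compound 2 to compound 3 (beyond the scatter) and thus beyond the scatter, whereas this first exchange of one halogen for another stays within it. Nothing measured here accounts for this result.

Going by these compounds, it remains open how a group of a different kind, such as an amine, a carboxylic acid or a longer chain, would read in this assay when placed on this same aromatic carbon, and whether any such group would move the number beyond the scatter. On these data alone, it is also open whether bromo in place of fluoro would give a similarly small step on a compound that carries a second fluoro, as compound 3 does, since the present step rests on a single pair.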